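The source may report more compounds than this note shows. Statements on the series, on what has been measured and on what is new or still open speak of the compounds shown alone.

In an ADME assay on L02 cells (Homo sapiens) for cytotoxicity, read by MTT assay, with a stated time of 24 h (on this read-out higher numbers stand for weaker inhibition and lower numbers for stronger inhibition), compound 1 (`CN1C/C(=C\c2cccnc2)C(=O)/C(=C/c2ccccc2F)C1`) gives 15900 nM, compound 2 (`CN1C/C(=C\c2cccnc2)C(=O)/C(=C/c2ccc(F)cc2Br)C1`) gives 14400 nM and compound 3 (`CN1C/C(=C\c2ccncc2)C(=O)/C(=C/c2ccccc2F)C1`) gives 14900 nM, so compound 3 stands level with the other two, all three values lying within the scatter of one another. Compound 4 (`CN1C/C(=C\c2ccncc2)C(=O)/C(=C/c2ccc(F)cc2Br)C1`) departs from compound 3 by one change: 2-bromo-4-fluorophenyl in place of 2-fluorophenyl on a double-bonded chain carbon bound to a double-bonded ring carbon. The same exchange was measured as the step of a 1.1-fold lower number from compound 1 to compound 2 (0.04 log units; within the scatter), which stayed within the scatter. The exchange of pyridin-3-yl for pyridin-4-yl, measured as the step of a 1.1-fold lower number from compound 1 to compound 3 (0.03 log units; within the scatter), also stayed within it. No step beyond the scatter is therefore expected in this assay, and the estimated step is a 1.1-fold lower number from compound 3 to compound 4 (0.04 log units; within the scatter). In this assay the estimate for compound 4 is 13500 nM, with an expected range from 8000 nM to 22000 nM.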

Compound 4, half-maximal inhibitory concentration: 12400 nM
Compound 4: the middle estimate sits 1.1-fold (0.04 log units) above what was measured; the range from low to high includes it.
By their numbers in this assay, from the lowest: compounds 4, 2, 3 and 1 (each within the scatter of the next).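

In this assay, the exchange of 2-fluorophenyl for 2-bromo-4-fluorophenyl gives a 1.2-fold lower number from compound 3 to compound 4 (0.08 log units; within the scatter), so with pyridin-4-yl present it also stays within the scatter: the same change on two cores in this assay, a 1.1-fold lower number (0.04 log units; within the scatter) from compound 1 to compound 2 and a 1.2-fold lower number (0.08 log units; within the scatter) from compound 3 to compound 4, 1.1-fold (0.04 log units) apart, within the scatter of two such steps. The exchange of pyridin-3-yl for pyridin-4-yl, now read with 2-bromo-4-fluorophenyl present, gives a 1.2-fold lower number from compound 2 to compound 4 (0.06 log units; within the scatter), and it agrees with its earlier step: the same change on two cores in this assay, a 1.1-fold lower number (0.03 log units; within the scatter) from compound 1 to compound 3 and a 1.2-fold lower number (0.06 log units; within the scatter) from compound 2 to compound 4, 1.1-fold (0.04 log units) apart, within the scatter of two such steps. Each change now stands on two pairs of compounds, and on neither pair does it step beyond the scatter. Going by these compounds, whether a group carrying an amine or a carboxylic acid, set in the same place, would step beyond the scatter stays open.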